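This account rests on a few compounds, and the source may have more. Where it says the series, first, only, none or still open, it means among the compounds named here.

Compound 1 `O=c1cc(Cc2c(F)cccc2F)nc(N2CCCC2)[nH]1` carries a pyrrolidin-1-yl group on an aromatic carbon of its core. In an ADME assay on MT4 cells (Homo sapiens) for cytotoxicity, read by MTT assay, with a stated time of 4 days (on this read-out higher numbers stand for lower toxicity in this test and lower numbers for higher toxicity in this test), compound 1 reaches only a limit of the test, > 86000 nM. Compound 2 `O=c1cc(Cc2c(F)cccc2F)nc(N2CCCCC2)[nH]1` differs from it by the change (piperidin-1-yl in place of pyrrolidin-1-yl on an aromatic carbon). In this assay compound 2 also gives a limit, > 82000 nM. The step that the two limits leave unreadable from compound 1 to compound 2 cannot be read, since both of its ends are limits. Compound 3 `Cc1c(C(C)c2c(F)cccc2F)nc(N2CCCC2)[nH]c1=O` has another core; how its core differs from that of compound 1 is not broken down here. In this assay compound 3 again reaches a limit, > 78000 nM. Compound 4 `Cc1c(C(C)c2c(F)cccc2F)nc(N2CCCCC2)[nH]c1=O` has not been measured and differs from compound 3 by the change (piperidin-1-yl in place of pyrrolidin-1-yl on an aromatic carbon). Among the compounds with values here, this is the same kind of change as the one from compound 1 to compound 2, though the place differs: in compound 3 the aromatic carbon is meta to a large group and para to a methyl group (1 heavy atom), while in compound 1 it is meta to a group of 9 heavy atoms. All three measured values sit at limits, as the limit of > 78000 nM in this assay, at which 1 of the 3 values shown sits, the limit of > 82000 nM in this assay, at which 1 of the 3 values shown sits, and the limit of > 86000 nM in this assay, at which 1 of the 3 values shown sits, show, so no size can be given for the measured step. In this assay the step that the limit leaves unreadable from compound 3 to compound 4 is expected to be small, resting on the unreadable step that the two limits leave unreadable from compound 1 to compound 2 between two limits. Compound 4 is expected to give 80000 nM, most likely again as a limit, within a range from 40000 nM to 200000 nM.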

Compound 4, half-maximal cytotoxic concentration: > 75000 nM
Compound 4 gave a limit, no number; the forecaster's own chance of this, stated with the estimate: 90%; the middle value lies beyond the limit too.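

Compound 3 and compound 4 both give only limits of the test, not numbers, and the step between these two compounds cannot be read. The compounds shown leave open how toxic any of them is in this assay, and whether piperidin-1-yl in place of pyrrolidin-1-yl changes that result at all on either core.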